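Taking the boron-bearing group out of compound 3

This account rests on a few compounds, and the source may have more. Where it says the series, first, only, none or still open, it means among the compounds named here.

In a functional assay on MDA-MB-231 cells (Homo sapiens) for antiproliferative activity, read by MTT assay, with a stated time of 72 h (on this read-out lower numbers stand for stronger inhibition and higher numbers for weaker inhibition), compound 3 `COc1cc(OC)cc(-c2cccc(NC(=O)CCc3cccc4c3B(O)OC4)c2)c1` gives 40 nM as the lowest of three numbers, with compound 2 `O=C(CCc1cccc2c1B(O)OC2)Nc1cccc(-c2ccc(Cl)cc2)c1` at 260 nM and compound 1 `O=C(CCc1cccc2c1B(O)OC2)Nc1cccc(-c2cccc(F)c2)c1` at 570 nM in the same series. Compound 4 `COc1cc(OC)cc(-c2cccc(NC(=O)CCc3ccccc3)c2)c1` keeps the 3,5-dimethoxyphenyl group, and its whole difference from compound 3 is a group of 6 heavy atoms (6 carbon; one six-membered aromatic ring of carbon only) in place of a group of 10 heavy atoms (7 carbon, 1 boron, 2 oxygen; one five-membered non-aromatic ring with 2 hetero atoms, one six-membered aromatic ring of carbon only), on a saturated chain carbon, two bonds along the chain from a carbonyl carbon with nothing else changed. The measured steps bear on this only indirectly. Changes of the group on an aromatic carbon gave a 2.2-fold lower number from compound 1 to compound 2 (0.34 log units; beyond the scatter) and a 6.5-fold lower number from compound 2 to compound 3 (0.81 log units; beyond the scatter) and also a 14-fold lower number from compound 1 to compound 3 (1.15 log units; beyond the scatter) in this series, but none of them touches the group that leaves here. Within the data shown here, no measured compound lacks that group, so the data hold no direct comparison. A large step toward a higher number is nonetheless expected in this assay as a judgement from the size of the replacement and not from any measured pair. The expected change is a 100-fold higher number from compound 3 to compound 4 (2.00 log units; beyond the scatter) by this estimate. Compound 4 is estimated at 4000 nM with a range of 500 nM to 30000 nM as the expected span.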

Compound 4, half-maximal inhibitory concentration: 87000 nM
Compound 4: the middle estimate sits 22-fold (1.34 log units) below what was measured; measured number above the stated range.
By their numbers in this assay, from the lowest: compound 3; then compound 2; then compound 1; then compound 4.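

In this assay, the step of a 2200-fold higher number from compound 3 to compound 4 (3.34 log units; beyond the scatter) gives the first measure of what the boron-bearing group contributes on the saturated chain carbon, two bonds along the chain from a carbonyl carbon. This step is larger than any step seen among compounds 1, 2 and 3, where only the group on the aromatic carbon changed, so in this small set the change at the chain position outweighs those changes. No available measurement shows why the loss is so large.

The compounds shown do not separate the boron atom from the rest of its ring, and a carboxylic acid or a hydroxymethyl group on the phenyl of compound 4 would test that question. They also leave open whether removing the boron-bearing group has a similar effect when 3-fluorophenyl or 4-chlorophenyl replaces the 3,5-dimethoxyphenyl group.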